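The compounds below may be only part of what the source reports. "The series", "measured", "known", "first", "only" and "open" are said of these compounds alone.

In an assay on isolated protein for inhibition of glucose-6-phosphatase catalytic subunit 1 (Homo sapiens), read by inositol phosphate accumulation, with a stated time of 30 min, tested at 100 uM (on this read-out higher numbers stand for more inhibition at the one concentration tested (going by the name of the read-out) and lower numbers for less inhibition), compound 1 `CCOC(=O)C1=CC(c2ccc(Cl)cc2)C2=C(CC(C)(C)CC2=O)N1` gives 11.3%.
Compound 2 `CC1(C)CC(=O)C2=C(C1)NC(C(=O)O)=CC2c1ccccc1` gives 17.1% in this assay.
Compound 3 `CCOC(=O)C1=CC(c2ccc(F)cc2)C2=C(CC(C)(C)CC2=O)N1` is reported in this assay as "not active" (no number reported), with no number.

All three measured compounds share one core, and the two that carry a number both sit low on the read-out: compound 1 and compound 2 fall within the usual scatter of each other, so neither number can be called higher or lower than the other. Compound 3 stands apart in that it has no single number at all; it is reported as not active, and so nothing can be said about its size relative to the other two.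

Compound 4 `CC1(C)CC(=O)C2=C(C1)NC(C(=O)O)=CC2c1ccc(F)cc1` has not yet been measured. It is reached from compound 3 by a single change: hydrogen in place of ethyl on an oxygen next to a carbonyl group. Going by the values given here, no measured pair shows this exact step on the shared core, so its size in this assay cannot be read from the data. The nearest hint is compound 2, which carries hydrogen on that oxygen and gives 17.1%, a low value. On that basis a low read-out is expected for compound 4, with any step from compound 3 likely to be none beyond the scatter. Compound 4 is therefore estimated at 12%, within a range from 0% to 28%.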

Compound 4, a percentage reported as inhibition, at one concentration (the size of the read-out at that concentration, not a potency): 16.8%
Beside the measured number, compound 4's estimate is 4.8 percentage points below it; measured number inside the range.
By their numbers in this assay, from the lowest: compounds 1, 4 and 2 (each within the scatter of the next).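

With the carboxy group kept, putting fluoro in place of hydrogen on an aromatic carbon gives a number 0.3 percentage points lower from compound 2 to compound 4 (within the scatter) in this assay and so, for this one pair, the read-out does not separate the two compounds. The change from ethoxycarbonyl to carboxy also now has a compound on each side: compound 3 is reported as not active, while compound 4 gives 16.8% in the same assay, but with no number for compound 3 the size of that step cannot be read. Nothing measured here offers a reason for either result.

The compounds shown leave open whether a different group on that aromatic carbon, such as methoxy or an amine, would move the read-out beyond the scatter when the carboxy group is present. They also leave open what would follow if the carboxy group itself gave way to a primary amide or a tetrazole, since only the carboxylic acid and its ethyl ester appear at that place.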